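Chain Extension in a Chloroacyl Anilide Series

The source may hold more compounds than are shown below. What is called first, only, known or untested is meant among the compounds shown, and "the series" means these compounds.

Of the compounds shown here, two have been measured. Compound 1 `CC(C)(C)c1ccc(NC(=O)NCCCCl)cc1` gives 49000 nM in a functional assay on MCF7 cells (Homo sapiens) for antiproliferative activity, with a stated time of 48 h (a higher number here means a weaker inhibitor, a lower number a stronger inhibitor), and compound 2 `CC(C)(C)c1ccc(NC(=O)CCCl)cc1` gives 49000 nM in this assay. The one measured step, no change at the digits printed from compound 1 to compound 2 (within the scatter), lies within the scatter, so compound 2 stands level with compound 1 at the digits shown and nowhere else on the scale.

Compound 3 `CC(C)(C)c1ccc(NC(=O)CCCCl)cc1` differs from compound 2 by chloromethyl in place of chloro on a saturated chain carbon, two bonds along the chain from a carbonyl carbon. Among the compounds with values here, the only step that bears on this change is no change at the digits printed from compound 1 to compound 2 (within the scatter), which altered the same carbonyl-bound chain and left the read-out unchanged within the scatter. On that basis the step from compound 2 to compound 3 in this assay is expected to be no change at the digits printed from compound 2 to compound 3 (within the scatter), with no direction beyond the scatter. Compound 3 is therefore estimated at 49000 nM in this assay, with a range from 20000 nM to 120000 nM.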

Compound 3, half-maximal inhibitory concentration: > 100000 nM
Compound 3: only a limit was reported; the forecaster's own chance of this, stated with the estimate: 20%; middle value at least 2.0-fold (0.30 log units) away from the limit.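

In this assay compound 3 is reported only as a limit, > 100000 nM. Chloromethyl in place of chloro on a saturated chain carbon, two bonds along the chain from a carbonyl carbon, gives an at least 2.0-fold higher number from compound 2 to compound 3 (0.30 log units; that floor lies within the scatter), and 3-chloropropyl in place of (3-chloropropyl)amino on a carbonyl carbon gives an at least 2.0-fold higher number from compound 1 to compound 3 (0.30 log units; that floor lies within the scatter). Unlike the earlier step between level values, these two steps have a direction but only a floor for their size, and both rest on a single reading at the end of the measured range: the limit of > 100000 nM in this assay, at which 1 of the 3 values shown sits.

As far as these compounds go, how far compound 3 truly lies from compound 2 remains open, and so does whether its floor understates a step beyond the scatter. A longer chain, or an amine or a hydroxyl in place of chloro, would show whether this position tolerates anything else.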